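This account rests on a few compounds, and the source may have more. Where it says the series, first, only, none or still open, it means among the compounds named here.

Measured so far:
compound 1 `CN(CCCn1ccnc1)C(=O)[C@@H]1CCCN1c1nccc(Nc2ccccc2)n1`: 0%
compound 2 `COC[C@@H]1CCCN1C(=O)[C@@H]1CCCN1c1cc(Nc2cccc(OC)c2)nc(N)n1`: 0%

In an assay on isolated protein for inhibition of calcium/calmodulin-dependent protein kinase type IV (Homo sapiens), read by HTRF, tested at 10 uM (a higher number here means more inhibition at the concentration tested (going by the name of the read-out), a lower number less inhibition), compound 1 gives 0% and stands level with compound 2, which gives 0% in this assay, within the scatter. Compound 3 `COC[C@@H]1CCCN1C(=O)[C@@H]1CCCN1c1nccc(Nc2ccccc2)n1` has not yet been measured in this assay. It differs from compound 1 in one place: 2-(methoxymethyl)pyrrolidin-1-yl in place of (3-(1H-imidazol-1-yl)propyl)(methyl)amino on a carbonyl carbon. Compound 2 already carries 2-(methoxymethyl)pyrrolidin-1-yl on a carbonyl carbon and gives 0% in this assay, so no step beyond the scatter is expected in either direction. Compound 3 is expected to give 0% in this assay, in the range -8% to 10%. The expected step is no change at the digits printed from compound 1 to compound 3 (within the scatter).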

Compound 3, a percentage reported as inhibition, at one concentration (the size of the read-out at that concentration, not a potency): 0%
For compound 3 middle estimate and measured number coincide at the digits printed; the measured number falls inside the stated range.
By their numbers in this assay, from the lowest: compounds 1, 2 and 3 (each within the scatter of the next).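

In this assay, putting 2-(methoxymethyl)pyrrolidin-1-yl in place of (3-(1H-imidazol-1-yl)propyl)(methyl)amino on a carbonyl carbon gives no change at the digits printed from compound 1 to compound 3 (within the scatter). This pair therefore shows that neither group gives the shared core any measurable inhibition, so the two groups cannot be ranked against each other. Nothing available offers an explanation for this result.

As far as these compounds go, whether any group at this place can produce inhibition remains open. A morpholine or a simple dimethylamino group there, for example, could still give a different reading.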